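Shifting a Fluorine on the Aryl Ring: Clearance Expectation

The source may report more compounds than this note shows. Statements on the series, on what has been measured and on what is new or still open speak of the compounds shown alone.

Compound 1, `COc1ccc(-c2c(S(=O)(=O)c3ccc(F)c(F)c3)cnc3cc(F)ccc23)cc1`, gives 1.1 mL/min in an ADME assay on microsomes from liver (Homo sapiens) for metabolic stability, tested at 2.5 uM; a higher number here means faster removal of the compound, a lower number slower removal.
Compound 2, `N#Cc1cccc(S(=O)(=O)c2cnc3cc(F)ccc3c2-c2ccccc2F)c1`, gives 1.39 mL/min.
Compound 3, `O=S(=O)(c1ccc(F)c(F)c1)c1cnc2cc(F)ccc2c1-c1cccc(F)c1`, gives 0.6 mL/min.

Compound 3 has the lowest of the three numbers; its gap to compound 1 lies within the scatter, while its gap to compound 2 lies beyond it. The change to compound 4, `O=S(=O)(c1ccc(F)c(F)c1)c1cnc2cc(F)ccc2c1-c1ccccc1F`, is 2-fluorophenyl in place of 3-fluorophenyl on an aromatic carbon. For the measured compounds named here, the only measured step on this same aromatic carbon, a 1.8-fold lower number from compound 1 to compound 3 (0.26 log units; within the scatter), stayed within the scatter, and compound 2 carries the same 2-fluorophenyl group but a different sulfonyl partner, so no direct comparison exists. The step of a 1.3-fold higher number from compound 3 to compound 4 (0.12 log units; within the scatter) is therefore expected to be small, if anything slightly upward. Compound 4 is estimated at 0.8 mL/min, with a range from 0.4 mL/min to 1.6 mL/min.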

Compound 4, intrinsic clearance in a liver preparation (reported as CLH), per the amount of preparation that the assay uses: 0.79 mL/min
The estimate for compound 4 lay 1.0-fold (0.01 log units) above the measured number; low and high end bracket the measured number.
By their numbers in this assay, from the lowest: compounds 3, 4, 1 and 2 (each within the scatter of the next, the first and the last beyond it).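

In this assay, moving the fluorine to give 2-fluorophenyl in place of 3-fluorophenyl produces a 1.3-fold higher number from compound 3 to compound 4 (0.12 log units; within the scatter) and so leaves the number within the scatter at this aromatic carbon. Compound 4 also stays within the scatter of both neighbours, with 2-fluorophenyl in place of 4-methoxyphenyl giving a 1.4-fold lower number from compound 1 to compound 4 (0.14 log units; within the scatter) and 3,4-difluorophenyl in place of 3-cyanophenyl on the sulfonyl sulfur giving a 1.8-fold lower number from compound 2 to compound 4 (0.25 log units; within the scatter).

On these data alone, whether an amine or a carboxylic acid on this aryl ring would move the number beyond the scatter stays open. Nothing at hand gives a reason for the size of these steps.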